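A few compounds are considered here, and "the series" means these few. Any claim that something is new, unique, unknown or untested is made for them only; others in the source may bear on it.

Measured compounds:
compound 1 `SC1=NC(n2nc(-c3ccccc3)nc2-c2ccccc2)=CC(c2ccccc2Cl)N1` — 300 mg/kg
compound 2 `O=[N+]([O-])c1cccc(C2C=C(n3cc(-c4ccccc4)nc3-c3ccccc3)N=C(S)N2)c1` — 300 mg/kg
compound 3 `CN(C)c1ccc(C2C=C(n3cc(-c4ccccc4)nc3-c3ccccc3)N=C(S)N2)cc1` — 300 mg/kg

All three were tested in a functional assay on the whole organism with Mus musculus as the target, in the maximal electroshock model, with a stated time of 4 h; on this read-out lower numbers stand for an effect already at smaller amounts and higher numbers for an effect only at larger amounts of compound. Compound 1 gives 300 mg/kg, and compounds 2 and 3 sit level with it; the differences among the three lie within the scatter of the method, so none can be called more or less active than another.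

The new compound is compound 4 `Oc1ccc(C2C=C(n3nc(-c4ccccc4)nc3-c3ccccc3)N=C(S)N2)cc1`. It differs from compound 1 in one place: 4-hydroxyphenyl in place of 2-chlorophenyl on a saturated ring carbon.

Going by the values given here, the only measured step that bears on this change is the swap of one aryl group for another on the same saturated ring carbon, going from compound 2 to compound 3, which gave no change at the digits printed from compound 2 to compound 3 (within the scatter). That exchange of two quite different aryl groups left this assay unchanged, and the three measured compounds together show no spread at all. On that basis no step beyond the scatter is expected from compound 1 to compound 4, that is no change at the digits printed from compound 1 to compound 4 (within the scatter).

Compound 4 is therefore estimated at 300 mg/kg, with a range from 100 mg/kg to 600 mg/kg, in this assay.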

Compound 4, minimum effective dose: 300 mg/kg
Beside the measured number, compound 4's estimate shows no gap at the digits printed, within the range that was stated.
By their numbers in this assay, from the lowest: compounds 1, 2, 3 and 4 (each within the scatter of the next).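

In this assay, the swap of 2-chlorophenyl for 4-hydroxyphenyl on the saturated ring carbon gives no change at the digits printed from compound 1 to compound 4 (within the scatter). The earlier aryl exchange belonged to the core of compounds 2 and 3, so this is the first step shown at this position on the core of compound 1, and here the entering group has a hydrogen-bond donor and acceptor while the leaving group has neither. No measurement shown here explains this result.

Going by these compounds, all four compounds carry an aryl group on this carbon and a sulfanyl group on the ring, so what an open chain such as butyl would do at the carbon remains unknown. Also open, on these data alone, is whether a carboxylic acid on the phenyl ring, or an amine in place of the sulfanyl group, would move the number in this assay.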